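Desmethyl analogue of compound 2 on the fused ring

The source may hold more compounds than are shown below. What is called first, only, known or untested is meant among the compounds shown, and "the series" means these compounds.

Two measured compounds anchor this series: compound 1 `COc1ccc(Cc2c(C)[nH]n(-c3nc4ccccc4[nH]3)c2=O)cc1` and compound 2 `Cc1ccc2[nH]c(-n3[nH]c(C)c(Cc4ccc(C(F)(F)F)cc4)c3=O)nc2c1`. Among the compounds with values here, they differ from each other in more than one place, so no single step joins them. In an assay on isolated protein for inhibition of alpha-ketoglutarate-dependent dioxygenase alkB homolog 3 (Homo sapiens), read by polymerase chain reaction, with a stated time of 1 h (on this read-out lower numbers stand for stronger inhibition and higher numbers for weaker inhibition), compound 1 gives 630 nM. In this assay compound 2 gives 570 nM, the lowest of the two numbers, but the gap to compound 1 is within the scatter, so the pair shows no order.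

Compound 3 `Cc1[nH]n(-c2nc3ccccc3[nH]2)c(=O)c1Cc1ccc(C(F)(F)F)cc1` is compound 2 with one change: hydrogen in place of methyl on an aromatic carbon. Within the data shown here, no measured pair covers this change, so its size is not known from data. A single methyl on the fused ring is a small change, and the expectation is a step that stays within the scatter, with at most a slight rise in the number.

Compound 3 is therefore expected to give about 700 nM in this assay, with a range from 300 nM to 1700 nM. The expected step is a 1.2-fold higher number from compound 2 to compound 3 (0.09 log units; within the scatter).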

Compound 3, half-maximal inhibitory concentration: 550 nM
Beside the measured number, compound 3's estimate is 1.3-fold (0.10 log units) above it, and the stated range covers the measured number.
By their numbers in this assay, from the lowest: compounds 3, 2 and 1 (each within the scatter of the next).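

Hydrogen in place of methyl on this aromatic carbon of the fused system gives a 1.0-fold lower number from compound 2 to compound 3 (0.02 log units; within the scatter) in this assay and provides the first measured pair for this change, one that cannot be told apart from the scatter. Trifluoromethyl in place of methoxy on an aromatic carbon gives a 1.1-fold lower number from compound 1 to compound 3 (0.06 log units; within the scatter) and is also within the scatter, so the three compounds, which earlier had no single-place link, are now joined by two single changes. Nothing measured here bears on the reasons for either result.

As far as these compounds go, with only hydrogen and methyl compared on the fused ring, it remains open whether an amine, a carboxylic acid or a longer chain such as propyl at that aromatic carbon would stay within the scatter of compound 3 or move the number beyond it. Methoxy and trifluoromethyl are likewise the only groups compared in the second change, so a nitrile or a hydroxyl group in that place remains an open comparison, as does any replacement of the methyl on the shared core.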